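Working notes: from 4-methylphenyl to phenyl

The compounds below may be only part of what the source reports. "The series", "measured", "known", "first", "only" and "open" are said of these compounds alone.

Values from a functional assay on A549 cells (Homo sapiens) for inhibition, read by CCK-8 assay, with a stated time of 72 h, tested at 1 uM (on this read-out higher numbers stand for more inhibition of growth at the one concentration tested and lower numbers for less inhibition of growth), follow.
- compound 1 `Cc1cccc(NC(=O)C2(C(=O)Nc3ccc(Nc4ncc5cc(C(=O)N(C)C)n(C6CCCC6)c5n4)cc3)CC2)c1` gives 35.2%
- compound 2 `CN(C)C(=O)c1cc2cnc(Nc3ccc(NC(=O)C4(C(=O)Nc5cccc(Cl)c5)CC4)cc3)nc2n1C1CCCC1` gives 8.3%
- compound 3 `Cc1ccc(NC(=O)C2(C(=O)Nc3ccc(Nc4ncc5cc(C(=O)N(C)C)n(C6CCCC6)c5n4)cc3)CC2)cc1` gives 40.2%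

Compound 3 shares the top of this set with compound 1 (a number 5 percentage points higher from compound 1 to compound 3 (within the scatter)) and stands clear of compound 2 (a number 31.9 percentage points higher from compound 2 to compound 3 (beyond the scatter)). Compound 4 `CN(C)C(=O)c1cc2cnc(Nc3ccc(NC(=O)C4(C(=O)Nc5ccccc5)CC4)cc3)nc2n1C1CCCC1` carries hydrogen in place of methyl on an aromatic carbon. Among the compounds with values here, no measured step removes a ring substituent outright. The two methyl isomers stay within the scatter of each other, while chloro in place of methyl gave a clear change (a number 26.9 percentage points lower from compound 1 to compound 2 (beyond the scatter)). A modest fall is therefore expected, with wide uncertainty (a number 12.2 percentage points lower from compound 3 to compound 4 (beyond the scatter)). Compound 4 is estimated at 28% in this assay (expected range 10% to 45%).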

Compound 4, percent growth inhibition at one concentration: 75%
Compound 4: the middle estimate sits 47 percentage points below what was measured, outside the stated range (above it).
By their numbers in this assay, from the lowest: compound 2; then compounds 1 and 3 (each within the scatter of the next); then compound 4.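

Hydrogen in place of a ring substituent gives the highest growth inhibition of the set in this assay (a number 34.8 percentage points higher from compound 3 to compound 4 (beyond the scatter); a number 39.8 percentage points higher from compound 1 to compound 4 (beyond the scatter); a number 66.7 percentage points higher from compound 2 to compound 4 (beyond the scatter)). The earlier compounds shown here only exchanged one substituent for another, whereas phenyl now stands clear of 4-methylphenyl, 3-methylphenyl and 3-chlorophenyl on the amide-type nitrogen, so each of these substituents goes with a lower number than hydrogen. Nothing available explains the size of this gain.

As far as these compounds go, it remains open whether any substituent on this ring can match hydrogen, for example a fluoro, a methoxy, an amine or a carboxylic acid. A single-concentration read-out also leaves open how far compound 4 stands from the others across a range of concentrations.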